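The source may report more compounds than this note shows. Statements on the series, on what has been measured and on what is new or still open speak of the compounds shown alone.

Of the compounds shown here, three that share one core have been tested in an ADME assay on the whole organism for inhibition, with Echinochloa crus-galli var. formosensis as the target, with a stated time of 4 days; on this read-out lower numbers stand for stronger inhibition and higher numbers for weaker inhibition. Compound 1 `CCN(c1nc(Cl)nc(N[C@H](C)c2ccccc2)n1)C(C)C` gives 52500 nM. Compound 2 `CCN(CC)c1nc(Cl)nc(N[C@H](C)c2ccccc2)n1` gives 24000 nM. Compound 3 `CC(C)Nc1nc(Cl)nc(N[C@H](C)c2ccccc2)n1` gives 2000 nM, the lowest of the three numbers. The difference methyl in place of hydrogen on a saturated chain carbon bound to a nitrogen on an aromatic ring and a saturated chain carbon produced a 2.2-fold higher number from compound 2 to compound 1 (0.34 log units; beyond the scatter). The two cores differ by isopropylamino in place of diethylamino on an aromatic carbon, a change that gave a 12-fold lower number from compound 2 to compound 3 (1.08 log units; beyond the scatter), and the further comparison gave a 26-fold lower number from compound 1 to compound 3 (1.42 log units; beyond the scatter). Compound 4 `CC[C@@H](C)Nc1nc(Cl)nc(N[C@H](C)c2ccccc2)n1` has not yet been measured. For the measured compounds named here, it differs from compound 3 by methyl in place of hydrogen on a saturated chain carbon, two bonds along the chain from a nitrogen on an aromatic ring, the same kind of change as the one that separates compound 2 and compound 1, though here the place is two bonds along the chain from a nitrogen on an aromatic ring rather than bound to a nitrogen on an aromatic ring and a saturated chain carbon. Because the earlier instance gave a 2.2-fold higher number from compound 2 to compound 1 (0.34 log units; beyond the scatter), a step of comparable size is expected for compound 4, estimated at a 1.8-fold higher number from compound 3 to compound 4 (0.24 log units; within the scatter). Compound 4 is therefore expected to give 3500 nM, with a likely range from 1200 nM to 10000 nM.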

Compound 4, half-maximal inhibitory concentration: 4570 nM
Compound 4: middle estimate off by 1.3-fold (0.12 log units), on the low side, within the range that was stated.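

In this assay the added methyl gave a modest step (a 2.3-fold higher number from compound 3 to compound 4 (0.36 log units; beyond the scatter)), and it matches the same change on the other core: the same change on two cores in this assay, a 2.2-fold higher number (0.34 log units; beyond the scatter) from compound 2 to compound 1 and a 2.3-fold higher number (0.36 log units; beyond the scatter) from compound 3 to compound 4, 1.0-fold (0.02 log units) apart, within the scatter of two such steps. Within these two pairs the change therefore carried over at a similar size, although its place on the chain differs, and the (sec-butyl)amino group of compound 4 still stands well below both tertiary amino compounds (a 5.3-fold lower number from compound 2 to compound 4 (0.72 log units; beyond the scatter); an 11-fold lower number from compound 1 to compound 4 (1.06 log units; beyond the scatter)). For the compounds shown here, this rests on only two pairs in a single assay, so it does not establish a general rule for the series, and it does not show what lies behind the step or whether it would hold on another core.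

The compounds shown leave open whether a longer chain such as pentyl, or a cyclopentyl group, on the amino nitrogen would extend the same trend. They also leave open whether the step would persist with a methoxy group in place of the chlorine.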